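Adding a third methoxy group to compound 1

A few compounds are considered here, and "the series" means these few. Any claim that something is new, unique, unknown or untested is made for them only; others in the source may bear on it.

- Compound 1 `COc1ccc(C(=O)/C=C/c2ccccc2-c2ccc(F)cc2)cc1OC`: 6600 nM
- Compound 2 `COc1ccc(C(=O)/C=C/c2ccccc2-c2ccc(F)nc2)cc1OC`: 17000 nM
- Compound 3 `COc1cc(C(=O)/C=C/c2ccccc2-c2ccc(F)cc2)ccc1O`: 3100 nM

In a functional assay on HepG2 cells (Homo sapiens) for antiproliferative activity, read by sulforhodamine B assay, with a stated time of 48 h (a higher number here means a weaker inhibitor, a lower number a stronger inhibitor), compound 1 gives 6600 nM, the middle of the three numbers. Compound 4 `COc1cc(C(=O)/C=C/c2ccccc2-c2ccc(F)cc2)cc(OC)c1OC` has not yet been measured. It differs from compound 1 by one change, methoxy in place of hydrogen on an aromatic carbon.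

Within the data shown here, no measured compound adds a methoxy group, so the evidence is indirect. The closer step alters a methoxy group, with hydrogen in place of methyl on an oxygen, and gives a 2.1-fold lower number from compound 1 to compound 3 (0.33 log units; beyond the scatter). The other step, 6-fluoropyridin-3-yl in place of 4-fluorophenyl, lies elsewhere in the molecule and gives a 2.6-fold higher number from compound 1 to compound 2 (0.41 log units; beyond the scatter). Both steps are modest and run in opposite directions, so neither sets a direction for the new change. Only a small shift is expected, slightly towards a lower number if at all. The estimated step is a 1.3-fold lower number from compound 1 to compound 4 (0.12 log units; within the scatter), which would stay within the scatter. For compound 4 the expected value is 5000 nM, with an estimated range from 2000 nM to 13000 nM.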

Compound 4, half-maximal inhibitory concentration: 12000 nM
For compound 4 the middle estimate is 2.4-fold (0.38 log units) below the measured one; low and high end bracket the measured number.
By their numbers in this assay, from the lowest: compound 3; then compounds 1, 4 and 2 (each within the scatter of the next, the first and the last beyond it).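

With the methoxy group added on this aromatic carbon, ortho to a methoxy group and meta to a large group, this assay shows a 1.8-fold higher number from compound 1 to compound 4 (0.26 log units; within the scatter), so the added group leaves the number within the scatter. Among these compounds, the earlier compounds only altered an existing methoxy group or exchanged the 4-fluorophenyl group; this result is the first to show that the core of compound 1 accepts a new methoxy group at this position without a change beyond the scatter. No available evidence bears on this result.

From the compounds shown here alone, it remains open whether an amine, a carboxylic acid or a longer alkoxy chain would be accepted at this position in the same way. Going by these compounds, it is also open whether the methoxy group would give a similar result with 6-fluoropyridin-3-yl in place of 4-fluorophenyl.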